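Swapping a Substituted Phenyl for Thiophene on the Core

The compounds below may be only part of what the source reports. "The series", "measured", "known", "first", "only" and "open" are said of these compounds alone.

Compound 1 `COc1cccc(-c2noc(COc3ccc(CCC(=O)O)cc3)n2)c1` carries a 3-methoxyphenyl on its shared core. In a functional assay on CHO cells for agonist activity at Free fatty acid receptor 1 (Homo sapiens), read by FLIPR and calcium flux, in the presence of a further agent that is not named here (on this read-out lower numbers stand for an effect already at smaller amounts and higher numbers for an effect only at larger amounts of compound), compound 1 gives 2670 nM, the highest of the three numbers measured here. Compound 3 `O=C(O)CCc1ccc(OCc2nc(-c3ccc(C(F)(F)F)cc3)no2)cc1` gives 610 nM in this assay, and compound 2 `O=C(O)CCc1ccc(OCc2coc(-c3cccc(F)c3)n2)cc1` gives 560 nM, so both of these sit well beyond the scatter from compound 1, with lower numbers meaning an effect at smaller amounts.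

Compound 4 `O=C(O)CCc1ccc(OCc2nc(-c3cccs3)no2)cc1` has not yet been measured. It differs from compound 1 in one place: thiophen-2-yl in place of 3-methoxyphenyl on an aromatic carbon. Within the data shown here, no measured pair here shows this exact change, so the expectation rests only on the spread among compounds 1, 2 and 3, all of which keep the same acid-bearing part and vary only the aromatic group on the core.

The step is expected to be modest, most likely toward a lower number, and is estimated as a 1.8-fold lower number from compound 1 to compound 4 (0.25 log units; within the scatter). Compound 4 is therefore estimated at 1500 nM in this assay, with a range from 500 nM to 4500 nM.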

Compound 4, half-maximal effective concentration: 2570 nM
The estimate for compound 4 lay 1.7-fold (0.23 log units) below the measured number; the measured number falls inside the stated range.
By their numbers in this assay, from the lowest: compounds 2 and 3 (each within the scatter of the next); then compounds 4 and 1 (each within the scatter of the next).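

Putting thiophen-2-yl in place of 3-methoxyphenyl on the shared core gives a 1.0-fold lower number from compound 1 to compound 4 (0.02 log units; within the scatter) in this assay, so this exchange produces no difference that can be read. Among these compounds, this one-place comparison shows that, on this read-out, a six-membered aromatic ring of carbon only and a five-membered aromatic ring with 1 hetero atom cannot be told apart at this position, something the earlier compounds could not show, as none of them differed from another in one place alone. Nothing measured here explains why the two groups match.

Going by these compounds, it remains open whether a group without an aromatic ring, such as cyclohexyl or a short alkyl chain, would also give a number like these. On these data alone, it is equally open how an amine or a chlorine atom on the thiophene ring would read in this assay.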